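Benzyl on the ring amine of compound 2

The source may hold more compounds than are shown below. What is called first, only, known or untested is meant among the compounds shown, and "the series" means these compounds.

compound 1 `O=c1ccccn1CC1CCCN(Cc2ccccc2)C1`: 1400 nM
compound 2 `O=c1ccccn1CC1CCNCC1`: 5400 nM

In an assay on HEK293 cells for displacement of a labelled ligand from Neuronal acetylcholine receptor; alpha4/beta4 (Rattus norvegicus), tested at 10 uM (a lower number here means a stronger inhibitor, a higher number a weaker inhibitor), compound 2 gives 5400 nM, the higher of the two numbers, and the gap to compound 1 at 1400 nM lies beyond the scatter. Compound 3 `O=c1ccccn1CC1CCN(Cc2ccccc2)CC1` keeps the core of compound 2 with benzyl in place of hydrogen on an amine nitrogen in a ring. For the measured compounds named here, no measured pair shows this change alone, as compound 1 and compound 2 differ in more than one place. A moderate fall of the number is expected, the step of a 2.7-fold lower number from compound 2 to compound 3 (0.43 log units; beyond the scatter). This rests on compound 1, which bears a benzyl on its ring amine and gives 1400 nM. Compound 3 is estimated at 2000 nM, within 700 nM to 6000 nM.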

Compound 3, inhibition constant: 4500 nM
For compound 3 the middle estimate is 2.3-fold (0.35 log units) below the measured one; the range from low to high includes it.
By their numbers in this assay, from the lowest: compound 1; then compounds 3 and 2 (each within the scatter of the next).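

In this assay, benzyl in place of hydrogen on the amine nitrogen in the ring can now be read alone, as a 1.2-fold lower number from compound 2 to compound 3 (0.08 log units; within the scatter). At this nitrogen, the seven added carbon atoms and the aromatic ring leave the two compounds indistinguishable. No data at hand bear on the reason for this result. Still open, going by these compounds, is whether a smaller group such as methyl, a longer chain such as phenethyl, or a benzyl carrying a methoxy or chlorine substituent would separate from compound 2 at this nitrogen.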